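Quinazolinylthio acetamide series: second chloro on the anilino ring

A few compounds are considered here, and "the series" means these few. Any claim that something is new, unique, unknown or untested is made for them only; others in the source may bear on it.

Measured compounds:
- compound 1, `C=CC(=O)Nc1cccc(NC(=O)CSc2nc(Nc3ccccc3Br)c3ccccc3n2)c1`: 17100 nM
- compound 2, `C=CC(=O)Nc1cccc(NC(=O)CSc2nc(Nc3ccc(Cl)cc3)c3ccccc3n2)c1`: 10800 nM

Both compounds were tested in a functional assay on PC-3 cells (Homo sapiens) for inhibition, read by MTT assay, with a stated time of 72 h; on this read-out lower numbers stand for stronger inhibition and higher numbers for weaker inhibition. Among the compounds with values here, compound 2 gives 10800 nM, the lowest of the two numbers, but its only neighbour, compound 1, stands within the scatter of it (a 1.6-fold lower number from compound 1 to compound 2 (0.20 log units; within the scatter)), so no order between the two can be claimed.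

Compound 3, `C=CC(=O)Nc1cccc(NC(=O)CSc2nc(Nc3ccc(Cl)c(Cl)c3)c3ccccc3n2)c1`, has not been measured. It differs from compound 2 by chloro in place of hydrogen on an aromatic carbon. Within the data shown here, the one step already in hand, from compound 1 to compound 2, swapped 2-bromophenyl for 4-chlorophenyl on the ring nitrogen and stayed within the scatter, which only shows that a change of the halogen pattern on this ring left the number roughly where it was. It is not the same change as the added chloro here, so it gives a weak guide. On this basis no step beyond the scatter is expected for compound 3 in this assay; the estimate for compound 3 is 8500 nM, within 3000 nM to 25000 nM, which is expected to mean a 1.3-fold lower number from compound 2 to compound 3 (0.10 log units; within the scatter).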

Compound 3, half-maximal inhibitory concentration: 27600 nM
Beside the measured number, compound 3's estimate is 3.2-fold (0.51 log units) below it, outside the stated range (above it).
By their numbers in this assay, from the lowest: compounds 2, 1 and 3 (each within the scatter of the next, the first and the last beyond it).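

In this assay, going from 4-chlorophenyl to 3,4-dichlorophenyl, with the new chloro ortho to the existing chloro group, gives a 2.6-fold higher number from compound 2 to compound 3 (0.41 log units; beyond the scatter). Within the data shown here, this is the first step beyond the scatter, modest in size and towards weaker inhibition, so this aromatic carbon is not indifferent to substitution in the way the earlier swap of halogen pattern might have suggested. Replacing 2-bromophenyl with 3,4-dichlorophenyl, by contrast, gives a 1.6-fold higher number from compound 1 to compound 3 (0.21 log units; within the scatter), so the one separation in the set is the one produced by adding this chloro, and nothing available bears on why the number moves with it.

On these data alone, it remains open whether the step is specific to chloro or would follow from any group on this carbon; a methoxy, an amine or a carboxylic acid in the same place would help separate those two readings. As far as these compounds go, with a single cell read-out, it also remains open whether the same step would appear in another cell line or in an assay on an isolated target.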